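Swapping an Aryl Amide for a Benzyl Amide

The compounds below may be only part of what the source reports. "The series", "measured", "known", "first", "only" and "open" are said of these compounds alone.

Compound 1, `CCCCCN1C(=O)C/C(=C\c2cccc(C(=O)Nc3ccc(C)cc3)c2)C1=O`: in an ADME assay on SW480 cells (Homo sapiens) for cytotoxicity, read by MTT assay, with a stated time of 72 h (a lower number here means a stronger inhibitor, a higher number a weaker inhibitor), compound 1 gives > 100000 nM, which is a limit of the assay rather than a number.
Compound 2, `CCc1ccc(NC(=O)c2cccc(/C=C3\CC(=O)N(c4ccccc4)C3=O)c2)cc1`: compound 2 gives > 100000 nM, likewise a limit.

Both values sit at the ceiling of this assay, as the limit of > 100000 nM in this assay, at which 2 of the 2 values shown sit, records. Going by the values given here, compound 2 therefore has no measured number of its own, and the one other value shown is a limit too. Compound 3, `O=C(NCc1ccccc1)c1cccc(/C=C2\CC(=O)N(c3ccccc3)C2=O)c1`, differs from compound 2 by benzyl in place of 4-ethylphenyl on an amide-type nitrogen. Among the compounds with values here, no measured step exists to lean on, so the change is expected to leave cytotoxicity in this assay where it is, with no step beyond the scatter. Compound 3 is expected to give 150000 nM, within 50000 nM to 500000 nM, and most probably to be reported again as a limit. The expected step that the limit leaves unreadable from compound 2 to compound 3 amounts to essentially no change.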

Compound 3, half-maximal inhibitory concentration: > 100000 nM
Compound 3 ended at the assay's limit; the forecaster's own chance of this, stated with the estimate: 85%; the middle value lies beyond the limit too.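

In this assay compound 2 and compound 3 both sit at a limit, so no step between them can be read: the limit of > 100000 nM in this assay, at which 3 of the 3 values shown sit.

The compounds shown leave open whether benzyl in place of 4-ethylphenyl on an amide-type nitrogen shifts cytotoxicity at all.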